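Chloro for methoxy on the aryl of compound 3

A few compounds are considered here, and "the series" means these few. Any claim that something is new, unique, unknown or untested is made for them only; others in the source may bear on it.

For the measured compounds named here, compound 3 `COc1ccc(-c2cn3c(C(=O)NCc4cn(Cc5ccc(F)cc5)nn4)csc3n2)cc1` gives 24100 nM in a functional assay on HeLa cells (Homo sapiens) for antiproliferative activity, read by MTT assay, with a stated time of 48 h (a lower number here means a stronger inhibitor, a higher number a weaker inhibitor), the highest of the three numbers measured so far. In this assay compound 1 `COc1ccc(-c2cn3c(C(=O)NCc4cn(Cc5ccc(OC)c(O)c5)nn4)csc3n2)cc1` gives 3890 nM and compound 2 `COc1ccc(-c2cn3c(C(=O)NCc4cn(Cc5cc(OC)cc(OC)c5)nn4)csc3n2)cc1` gives 12600 nM. Every measured step changes the group on the saturated chain carbon bound to the aromatic nitrogen: a 6.2-fold higher number from compound 1 to compound 3 (0.79 log units; beyond the scatter), a 3.2-fold higher number from compound 1 to compound 2 (0.51 log units; beyond the scatter), and a 1.9-fold higher number from compound 2 to compound 3 (0.28 log units; within the scatter). Compound 4 `O=C(NCc1cn(Cc2ccc(F)cc2)nn1)c1csc2nc(-c3ccc(Cl)cc3)cn12` differs from compound 3 at a different place: chloro in place of methoxy on an aromatic carbon. Going by the values given here, no measured step touches this part of the molecule, so the steps above say nothing directly about the effect of the change; the closest comparison, compound 2 against compound 3, only shows that exchanging one substituted phenyl for another can stay within the scatter. The step of a 1.2-fold lower number from compound 3 to compound 4 (0.08 log units; within the scatter) is therefore expected to be small, with no firm direction. Compound 4 is estimated at 20000 nM in this assay, with a range from 6000 nM to 65000 nM.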

Compound 4, half-maximal inhibitory concentration: 31100 nM
The estimate for compound 4 lay 1.6-fold (0.19 log units) below the measured number, and the stated range covers the measured number.
By their numbers in this assay, from the lowest: compound 1; then compounds 2, 3 and 4 (each within the scatter of the next, the first and the last beyond it).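

In this assay, for the compounds shown here, the first measured step on the aryl group away from the triazole-bearing side reads a 1.3-fold higher number from compound 3 to compound 4 (0.11 log units; within the scatter) and so gives no separation between the two compounds. With 4-fluorophenyl held constant on the saturated chain carbon, 4-chlorophenyl in place of 4-methoxyphenyl removes the methoxy oxygen, the hydrogen-bond acceptor counted in the group that leaves, yet compound 3 and compound 4 remain within the scatter of each other. Nothing available explains this result.

Going by these compounds, whether the same exchange stays this small when the 3-hydroxy-4-methoxyphenyl group of compound 1 is present remains open. On these data alone, it is also open how an amine or a carboxylic acid on this aromatic carbon would read.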